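The source may hold more compounds than are shown below. What is called first, only, known or untested is meant among the compounds shown, and "the series" means these compounds.

For the measured compounds named here, compound 2 `Cc1cccc(-c2ncc3ccc(C)nc3n2)c1` gives the lowest of the two numbers measured so far in a functional assay on CHO cells for antagonist activity at metabotropic glutamate receptor 5 (Rattus norvegicus), read by FLIPR and calcium flux (a lower number here means a stronger inhibitor, a higher number a weaker inhibitor), where compound 2 gives 53 nM. Going by the values given here, the only other measured compound, compound 1 `Cc1ccc2cnc(-c3ccccc3)nc2n1`, gives 2700 nM in this assay. Compound 3 `Cc1cc(F)cc(-c2ncc3ccc(C)nc3n2)c1` differs from compound 2 by fluoro in place of hydrogen on an aromatic carbon. Among the compounds with values here, the single measured step, a 51-fold lower number from compound 1 to compound 2 (1.71 log units; beyond the scatter), concerns a different change and does not bear directly on adding fluoro. Within the data shown here, with no comparable step known, compound 3 is expected to change little, a 1.3-fold lower number from compound 2 to compound 3 (0.12 log units; within the scatter). The estimate for compound 3 is 40 nM, within 10 nM to 160 nM.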

Compound 3, half-maximal inhibitory concentration: 39.7 nM
Compound 3: middle estimate off by 1.0-fold (0.00 log units), on the high side; low and high end bracket the measured number.
By their numbers in this assay, from the lowest: compounds 3 and 2 (each within the scatter of the next); then compound 1.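

In this assay, fluoro in place of hydrogen on this aromatic carbon, meta to a large group and meta to a methyl group, gives a 1.3-fold lower number from compound 2 to compound 3 (0.13 log units; within the scatter), so compound 2 and compound 3 cannot be told apart. For the compounds shown here, this carbon of the ring therefore accepts a fluoro with no measurable change in the number, whereas the only earlier step concerned a methyl group. No supporting measurement bears on the cause of this result. Going by these compounds, whether an amine or a methoxy group on the same carbon would leave the number equally unchanged remains open. So does whether fluoro would behave the same way on another carbon of this ring.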